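A few compounds are considered here, and "the series" means these few. Any claim that something is new, unique, unknown or untested is made for them only; others in the source may bear on it.

In an assay on CHO cells for displacement of a labelled ligand from adenosine receptor A3 (Homo sapiens), read by scintillation counting, with a stated time of 120 min, tested at 1 uM (on this read-out higher numbers stand for more inhibition at the one concentration tested (going by the name of the read-out) and lower numbers for less inhibition), compound 1 `N#Cc1c(N)nc(SCc2cccc(C(N)=O)c2)c(C#N)c1-c1ccc(OCC2CC2)cc1` gives 1%, compound 2 `N#Cc1c(N)nc(SCc2nnn[nH]2)c(C#N)c1-c1ccc(OCC2CC2)cc1` gives 1% and compound 3 `N#Cc1c(N)nc(SCc2csc(N)n2)c(C#N)c1-c1ccc(OCC2CC2)cc1` gives 1%. Compound 3 stands level with both at the digits shown: the steps of no change at the digits printed from compound 1 to compound 3 (within the scatter) and no change at the digits printed from compound 2 to compound 3 (within the scatter), like no change at the digits printed from compound 1 to compound 2 (within the scatter), all lie within the scatter. Compound 4 `COC(=O)CSc1nc(N)c(C#N)c(-c2ccc(OCC3CC3)cc2)c1C#N` has not been measured. It differs from compound 3 as follows: methoxycarbonyl in place of 2-amino-1,3-thiazol-4-yl on a saturated chain carbon bound to a sulfur. The three measured steps also exchanged the group on a saturated chain carbon bound to a sulfur, and none of them moved the read-out; the present change goes further in bringing in a group without a ring, but the series offers no ground for expecting any shift. In this assay compound 4 is therefore expected to give 1% (range -8% to 12%), an estimated step of no change at the digits printed from compound 3 to compound 4 (within the scatter) within the scatter.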

Compound 4, a percentage reported as inhibition, at one concentration (the size of the read-out at that concentration, not a potency): 1%
Beside the measured number, compound 4's estimate shows no gap at the digits printed; the range from low to high includes it.
By their numbers in this assay, from the lowest: compounds 1, 2, 3 and 4 (each within the scatter of the next).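

In this assay, going by these compounds alone, methoxycarbonyl is the first group on a saturated chain carbon bound to a sulfur with no ring, and it gives no change at the digits printed from compound 3 to compound 4 (within the scatter), no change at the digits printed from compound 2 to compound 4 (within the scatter) and no change at the digits printed from compound 1 to compound 4 (within the scatter). A group without a ring therefore reads the same here as the three ring-bearing groups. No available evidence bears on why this position stays flat.

From the compounds shown here alone, whether a carboxylic acid, a primary amine or a longer alkyl chain at this place would raise the inhibition remains open. So does whether replacing the cyclopropylmethoxy group would do so.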